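The source may report more compounds than this note shows. Statements on the series, on what has been measured and on what is new or still open speak of the compounds shown alone.

In a functional assay on HT-29 cells (Homo sapiens) for inhibition, read by CCK-8 assay, with a stated time of 24 h (a higher number here means a weaker inhibitor, a lower number a stronger inhibitor), compound 1 `O=C1Nc2ccccc2/C1=C/c1ccc(-c2cn(-c3ccc(Cl)c(C(F)(F)F)c3)nn2)cc1` gives 9670 nM as its half-maximal inhibitory concentration, compound 2 `Cc1ccccc1-n1cc(-c2ccc(C=C3C(=O)Nc4ccc(F)cc43)cc2)nn1` gives 5870 nM and compound 3 `Cc1ccc(-n2cc(-c3ccc(/C=C4\C(=O)Nc5ccc(F)cc54)cc3)nn2)cc1` gives 3980 nM on the same read-out. Compound 2 stands within the usual scatter of both compound 1 and compound 3, so the numbers do not set it apart from either. Compound 4 `N#Cc1ccc(-n2cc(-c3ccc(C=C4C(=O)Nc5ccc(F)cc54)cc3)nn2)cc1` carries 4-cyanophenyl in place of 2-methylphenyl on an aromatic nitrogen and has not yet been measured. Among the compounds with values here, no measured pair isolates this change, so no direction can be given and no step beyond the scatter is expected in this assay for it. The expected step is a 1.2-fold lower number from compound 2 to compound 4 (0.07 log units; within the scatter) and it is estimated to stay within the scatter. Compound 4 is expected at 5000 nM with an estimated range from 2000 nM to 12000 nM around that figure.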

Compound 4, half-maximal inhibitory concentration: 20000 nM
For compound 4 the middle estimate is 4.0-fold (0.60 log units) below the measured one, outside the stated range (above it).
By their numbers in this assay, from the lowest: compounds 3, 2 and 1 (each within the scatter of the next, the first and the last beyond it); then compound 4.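

In this assay, within the data shown here, replacing 2-methylphenyl with 4-cyanophenyl on the aromatic nitrogen gives a 3.4-fold higher number from compound 2 to compound 4 (0.53 log units; beyond the scatter), the first single-place change in this set and a modest one. Among these compounds, it shows that the group at this position can shift the number towards a weaker inhibitor, which the earlier compounds, with no pair differing in one place, could not show. Nothing given here bears on the cause of this step. Open, from the compounds shown here alone, is how an aminophenyl or a carboxyphenyl group would read here, and whether the entering nitrile or the leaving methyl group carries the step.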